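The compounds below may be only part of what the source reports. "The series", "measured", "known", "first", "only" and "open" are said of these compounds alone.

In an ADME assay on HEK-293T cells (Homo sapiens) for cytotoxicity, read by luminescence, with a stated time of 24 h (a lower number here means that less compound is tolerated, a higher number that more compound is tolerated), compound 1 `COc1ccc(Cn2c(C(=O)NCc3ccccc3)cc3sccc32)cc1` gives > 100000 nM as a limit of the assay, not a number. Going by the values given here, compound 2 `CCOC(=O)C1CCN(C(=O)c2cc3sccc3n2Cc2ccc(OC)cc2)CC1` gives 39000 nM as the only actual number so far, so it has no measured neighbour to be ranked against. Compound 3 `COc1ccc(Cn2c(C(=O)N3CCC(C(=O)NC4CC4)CC3)cc3sccc32)cc1` has cyclopropylamino in place of ethoxy on a carbonyl carbon. Among the compounds with values here, no measured pair of compounds shows what this change does, so the expectation is cautious. A modest step of a 1.5-fold higher number from compound 2 to compound 3 (0.19 log units; within the scatter) is expected, towards more compound being tolerated. Compound 3 is estimated at 60000 nM (expected range 25000 nM to 100000 nM).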

Compound 3, half-maximal cytotoxic concentration: 21400 nM
Compound 3: middle estimate off by 2.8-fold (0.45 log units), on the high side, outside the stated range (below it).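

In this assay replacing ethoxy with cyclopropylamino on a carbonyl carbon gives a 1.8-fold lower number from compound 2 to compound 3 (0.26 log units; within the scatter) and so no change that stands clear of the scatter. Ethoxycarbonyl can thus give way to cyclopropylcarbamoyl, which brings in a hydrogen-bond donor and a three-membered ring, with no clear shift in the tolerated concentration. Going by these compounds alone, this is the first step that can be read at this position, and neither of its compounds sits at the limit: the limit of > 100000 nM in this assay, at which 1 of the 3 values shown sits.

Going by these compounds, what a carboxylic acid or a longer chain on this carbonyl carbon would do stays open. So does whether the ring or the amide hydrogen matters on its own.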